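Changing the Ring on the Aromatic Nitrogen

The source may hold more compounds than are shown below. What is called first, only, known or untested is meant among the compounds shown, and "the series" means these compounds.

Three close relatives of one shared core have been measured in a functional assay on PC-12 cells (Rattus norvegicus) for cytotoxicity, read by MTT assay, with stated times of 2 h and 24 h, tested at 1 uM; a lower number here means a weaker effect, a higher number a stronger effect of the compound at the concentration tested. Compound 1 `Oc1cc(C(F)(F)F)ccc1-c1nc(-c2ccccc2O)n(-c2ccc(F)cc2)n1` gives 67.2%. Compound 2 `Oc1cc(C(F)(F)F)ccc1-c1nc(-c2ccccc2O)n(-c2ccc(Br)cc2)n1` gives 69.4%, and compound 3 `Oc1cc(C(F)(F)F)ccc1-c1nc(-c2ccccc2O)n(-c2ccc(F)cc2F)n1` gives 65.9%. Compound 2 has the highest of the three numbers, but the gaps are small: a number 2.2 percentage points higher from compound 1 to compound 2 (within the scatter) and a number 3.5 percentage points lower from compound 2 to compound 3 (within the scatter) are both within the scatter, and the remaining step, a number 1.3 percentage points lower from compound 1 to compound 3 (within the scatter), lies within it as well.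

Compound 4 `Cc1cc(C)cc(-n2nc(-c3ccc(C(F)(F)F)cc3O)nc2-c2ccccc2O)c1` has not yet been measured. It differs from compound 2 in one place: 3,5-dimethylphenyl in place of 4-bromophenyl on an aromatic nitrogen. The measured step most like this one is the step in which a 2,4-difluorophenyl took the place of a 4-bromophenyl on the same aromatic nitrogen, and that step was a number 3.5 percentage points lower from compound 2 to compound 3 (within the scatter). Swapping bromo for fluoro on that ring, a number 2.2 percentage points higher from compound 1 to compound 2 (within the scatter), also moved the number only within the scatter. Nothing among these three compounds shows that the group on this nitrogen changes the read-out beyond the usual noise, so no step beyond the scatter is expected: the estimated change is a number 2.4 percentage points lower from compound 2 to compound 4 (within the scatter). Compound 4 is therefore expected to give 67%, with a likely range from 57% to 77%.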

Compound 4, a percentage reported as activity, at one concentration (the size of the read-out at that concentration, not a potency): 76.9%
Compound 4: the middle estimate sits 9.9 percentage points below what was measured, and the stated range covers the measured number.
By their numbers in this assay, from the lowest: compounds 3, 1, 2 and 4 (each within the scatter of the next, the first and the last beyond it).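

Among these compounds, the group on this aromatic nitrogen has now moved the read-out beyond the scatter in this assay, with a modest step of a number 11 percentage points higher from compound 3 to compound 4 (beyond the scatter), as 3,5-dimethylphenyl replaced 2,4-difluorophenyl. This separation is limited to that one pair, since the steps of a number 7.5 percentage points higher from compound 2 to compound 4 (within the scatter) and a number 9.7 percentage points higher from compound 1 to compound 4 (within the scatter) both stay within the scatter, so compound 4 cannot be told apart from either of those halogen-bearing compounds, which go against any simple rule that a dimethyl-substituted ring beats a halogenated one. Going by these compounds alone, no measurement available here gives a reason for the one step that passes the scatter.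

As far as these compounds go, all four groups at this position are phenyl rings carrying halogen or methyl substituents, so it remains open whether a ring bearing an amine or a carboxylic acid, or a longer alkyl chain in place of the ring, would shift the read-out further. From the compounds shown here alone, it also remains open whether a phenyl ring with a single methyl would behave like 3,5-dimethylphenyl, and whether the modest step seen here would hold at other concentrations.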